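The compounds below may be only part of what the source reports. "The series", "measured", "known", "first", "only" and "open" are said of these compounds alone.

Working notes on the series. The shared core is carried by compound 1, whose structure is `O=C(/C=C\c1ccc(O)cc1)N1N=C(c2ccncc2)OC1c1c[nH]c2ccccc12`. In an ADME assay on HeLa cells (Homo sapiens) for cytotoxicity, read by MTT assay, with a stated time of 72 h (on this read-out higher numbers stand for weaker inhibition of growth and lower numbers for stronger inhibition of growth), compound 1 gives > 30 ug/mL, which is a limit of the assay and not a number. Compound 2, `O=C(/C=C\c1ccccc1F)N1N=C(c2ccncc2)OC1c1c[nH]c2ccccc12`, gives > 30 ug/mL in this assay, again only a limit. Compound 3, `O=C(/C=C\c1ccc(F)cc1)N1N=C(c2ccncc2)OC1c1c[nH]c2ccccc12`, gives > 30 ug/mL in this assay, also a limit. Where compound 1 stands is thus known only as a limit, and every measured value sits at the limit of > 30 ug/mL in this assay, at which 3 of the 3 values shown sit. The steps a step that the two limits leave unreadable from compound 1 to compound 2, a step that the two limits leave unreadable from compound 1 to compound 3 and a step that the two limits leave unreadable from compound 2 to compound 3 cannot be sized, since both ends of each are limits.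

Compound 4 is `O=C(/C=C/c1c(Cl)cccc1Cl)N1N=C(c2ccncc2)OC1c1c[nH]c2ccccc12`, not yet measured. It differs from compound 1 in one place: 2-(2,6-dichlorophenyl)ethenyl in place of 2-(4-hydroxyphenyl)ethenyl on a carbonyl carbon. The measured steps that bear on this change are the three above, each a swap on the 2-(4-hydroxyphenyl)ethenyl group, and none gave a readable size. The expectation for compound 4 in this assay is therefore no step beyond the scatter, and most probably another limit rather than a number. Compound 4 is estimated at about 40 ug/mL, with a range from 15 ug/mL to 120 ug/mL. Among the measured compounds shown here, the expected step is a step that the limit leaves unreadable from compound 1 to compound 4, estimated because the limit of > 30 ug/mL in this assay, at which 3 of the 3 values shown sit, holds all three values so far.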

Compound 4, concentration for 50% growth inhibition: > 30 ug/mL
Compound 4: only a limit was reported; the forecaster's own chance of this, stated with the estimate: 65%; the middle value lies beyond the limit too.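

In this assay compound 4 gives > 30 ug/mL, a limit of the assay and not a number. No step from compound 1, compound 2 or compound 3 to compound 4 can be read, because both ends of each are limits: the limit of > 30 ug/mL in this assay, at which 4 of the 4 values shown sit.

The compounds shown leave open whether any swap on the ethenyl group changes growth inhibition in this assay.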